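Swapping the Aryl Group at the Fused Ring: Stability Outlook

The source may report more compounds than this note shows. Statements on the series, on what has been measured and on what is new or still open speak of the compounds shown alone.

Measured so far:
compound 1 `O=C(NCCCCc1ccccc1)n1c(=O)oc2ccccc21`: 0.75 h
compound 2 `COc1ccc(-c2ccc3c(c2)oc(=O)n3C(=O)NCCCCc2ccccc2)cc1`: 2.2 h

Going by the values given here, in a physicochemical assay for metabolic stability, read by HPLC, in phosphate buffer, at pH 7.4, tested at 10 uM (on this read-out lower numbers stand for a shorter-lived compound and higher numbers for a longer-lived compound), compound 2 holds the highest of the two numbers; the only neighbour is compound 1, which sits a 2.9-fold higher number from compound 1 to compound 2 (0.47 log units; beyond the scatter) below it. Compound 3 `O=C(c1ccc(Cl)cc1)c1ccc2c(c1)oc(=O)n2C(=O)NCCCCc1ccccc1` differs from compound 2 in one place: (4-chlorophenyl)carbonyl in place of 4-methoxyphenyl on an aromatic carbon. Among the compounds with values here, only that one step bears on this change, and it shows a modest gain from a bare aromatic carbon to a 4-methoxyphenyl; no measured step shows a (4-chlorophenyl)carbonyl. A substituted position is kept, so compound 3 is expected to stay near compound 2, with a step of a 1.1-fold lower number from compound 2 to compound 3 (0.04 log units; within the scatter). The estimate for compound 3 is 2 h, ranging from 0.9 h to 4.5 h.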

Compound 3, half-life: 4.57 h
Estimate against measurement, compound 3: 2.3-fold (0.36 log units) below; measured number outside the range, above it.
By their numbers in this assay, from the lowest: compound 1; then compound 2; then compound 3.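

So the group on this aromatic carbon still matters once the hydrogen is replaced: exchanging 4-methoxyphenyl for (4-chlorophenyl)carbonyl gives a 2.1-fold higher number from compound 2 to compound 3 (0.32 log units; beyond the scatter). Measured against the unsubstituted core, the (4-chlorophenyl)carbonyl group gives a 6.1-fold higher number from compound 1 to compound 3 (0.78 log units; beyond the scatter), a larger step than 4-methoxyphenyl gave. No measurement available here explains why the half-life changes with this swap. As far as these compounds go, it remains open whether the carbonyl or the chlorine accounts for the gain, and how an amine or a carboxylic acid on this same aromatic carbon would compare.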